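Nitro in place of hydrogen on an inactive core

A few compounds are considered here, and "the series" means these few. Any claim that something is new, unique, unknown or untested is made for them only; others in the source may bear on it.

Measured compounds in a functional assay on HeLa cells (Homo sapiens) for cytotoxicity, with a stated time of 72 h; on this read-out higher numbers stand for weaker inhibition and lower numbers for stronger inhibition:
Compound 1 `Fc1ccc(-c2nc3sc(Cc4ccc(Cl)cc4)nn3c2Br)cc1` gives > 250000 nM, a limit of the assay.
Compound 2 `Cc1ccc(-c2nc3sc(Cc4ccc(Cl)cc4)nn3c2Br)cc1` gives > 250000 nM, a limit of the assay.
Compound 3 `Clc1ccc(Cc2nn3c(Br)c(-c4ccccc4)nc3s2)cc1` gives > 250000 nM, a limit of the assay.

Compound 3 stands where its two neighbours stand. Its value in this assay is a limit, not a number, so its true potency lies somewhere beyond what the assay could resolve. The three measured steps, a step that the two limits leave unreadable from compound 1 to compound 2, a step that the two limits leave unreadable from compound 1 to compound 3 and a step that the two limits leave unreadable from compound 2 to compound 3, are each unreadable for the same reason: both ends of every step are limits. For the measured compounds named here, the only evidence across the series is the limit of > 250000 nM in this assay, at which 3 of the 3 values shown sit, which says that none of the three compounds reached measurable cytotoxicity.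

Compound 4 `O=[N+]([O-])c1ccc(-c2nc3sc(Cc4ccc(Cl)cc4)nn3c2Br)cc1` carries one change relative to compound 3: nitro in place of hydrogen on an aromatic carbon. Going by the values given here, no measured step involves a nitro group, and the steps that exist give no size to build on. The expectation therefore rests only on the shared behaviour of compounds 1, 2 and 3. Compound 4 is estimated at 250000 nM, with a range from 100000 nM to 600000 nM, most probably again a limit. The expected step of a number no higher from compound 3 to compound 4 (the limit leaves the size open) is none beyond the scatter.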

Compound 4, half-maximal inhibitory concentration: > 250000 nM
Compound 4 was reported as a limit (the forecaster's own chance of this, stated with the estimate: 85%); the middle value lies on the limit itself.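

Compound 4, like compound 1, compound 2 and compound 3, is reported only as a limit in this assay, so none of the steps joining these four compounds can be read: the limit of > 250000 nM in this assay, at which 4 of the 4 values shown sit. The compounds shown leave open how far apart their true potencies lie, and whether any group in this place could bring measurable cytotoxicity.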